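Adding a third fluoro to the difluorophenyl group

The source may report more compounds than this note shows. Statements on the series, on what has been measured and on what is new or still open speak of the compounds shown alone.

Measured so far:
compound 1 `COc1cc2c(Oc3ccc(NC(=O)NN4C(=O)CSC4c4ccccc4F)cc3)ccnc2cc1OC1CCN(C(=O)NC(C)C)CC1`, 410 nM
compound 2 `COc1cc2c(Oc3ccc(NC(=O)NN4C(=O)CSC4c4ccc(F)cc4F)cc3)ccnc2cc1OC1CCN(C(=O)NC(C)C)CC1`, 950 nM

In a functional assay on HT-29 cells (Homo sapiens) for inhibition, read by MTT assay (on this read-out higher numbers stand for weaker inhibition and lower numbers for stronger inhibition), compound 2 gives 950 nM, the highest of the two numbers; the nearest is compound 1 at 410 nM. Compound 3 `COc1cc2c(Oc3ccc(NC(=O)NN4C(=O)CSC4c4c(F)cc(F)cc4F)cc3)ccnc2cc1OC1CCN(C(=O)NC(C)C)CC1` differs from compound 2 by fluoro in place of hydrogen on an aromatic carbon. For the measured compounds named here, the only step that bears on this change is a 2.3-fold higher number from compound 1 to compound 2 (0.36 log units; beyond the scatter), the same kind of substitution on the same ring. A further step of similar size and in the same direction is expected. For compound 3 the estimate in this assay is 1800 nM, within 800 nM to 4000 nM. This expected change corresponds to a 1.9-fold higher number from compound 2 to compound 3 (0.28 log units; within the scatter).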

Compound 3, half-maximal inhibitory concentration: 910 nM
Beside the measured number, compound 3's estimate is 2.0-fold (0.30 log units) above it, and the stated range covers the measured number.
By their numbers in this assay, from the lowest: compound 1; then compounds 3 and 2 (each within the scatter of the next).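

In this assay, going from 2,4-difluorophenyl to 2,4,6-trifluorophenyl gives a 1.0-fold lower number from compound 2 to compound 3 (0.02 log units; within the scatter), so fluoro at this position, ortho to a large group and meta to two fluoro groups, does not repeat the earlier step. Measured against the 2-fluorophenyl compound, the trifluorinated ring still shows a 2.2-fold higher number from compound 1 to compound 3 (0.35 log units; beyond the scatter) and stays on the higher side. No measurement available here accounts for this result. Still open, going by these compounds, is whether chloro, methyl or methoxy at this position would read like fluoro, and where the plain phenyl ring stands.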